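Sulfonamide series: methoxy in place of ethyl

A few compounds are considered here, and "the series" means these few. Any claim that something is new, unique, unknown or untested is made for them only; others in the source may bear on it.

Measured compounds:
Compound 1 `CC(C)(C)c1ccc(NS(=O)(=O)c2ccc(N3CCNC3=O)cc2)cc1`. In a functional assay on HT-29 cells (Homo sapiens) for antiproliferative activity, read by sulforhodamine B assay, with a stated time of 48 h (a higher number here means a weaker inhibitor, a lower number a stronger inhibitor), compound 1 sits at > 1000 nM, which is a limit of the assay and not a number.
Compound 2 `CCc1cccc(NS(=O)(=O)c2ccc(N3CCNC3=O)cc2)c1`. In this assay compound 2 gives 110 nM.
Compound 3 `CCCCOc1ccc(NS(=O)(=O)c2ccc(N3CCNC3=O)cc2)cc1`. In this assay compound 3 gives 630 nM.

Compound 2 holds the lowest number of the two measured values; compound 3 stands a clear distance higher, beyond the scatter, and compound 1 is known only as a limit (the limit of > 1000 nM in this assay, at which 1 of the 3 values shown sits).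

For the measured compounds named here, the only measured step is an at least 1.5-fold lower number from compound 1 to compound 3 (0.20 log units; that floor lies within the scatter), and it compares two groups on a different position of the ring from the one changed here; it says only that an alkoxy group is tolerated at that place. Going by the values given here, no measured step covers the change from compound 2 to compound 4 `COc1cccc(NS(=O)(=O)c2ccc(N3CCNC3=O)cc2)c1`, which is methoxy in place of ethyl on an aromatic carbon. Both groups are small and sit on an aromatic carbon of a six-membered aromatic ring of carbon only, meta to a large group.

Among the compounds with values here, with no direct precedent, the expectation for compound 4 is a step of no more than modest size, and if anything toward a higher number, a 1.8-fold higher number from compound 2 to compound 4 (0.26 log units; within the scatter). Compound 4 is therefore estimated at 200 nM in this assay, with a range from 60 nM to 700 nM.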

Compound 4, half-maximal inhibitory concentration: 120 nM
The estimate for compound 4 lay 1.7-fold (0.22 log units) above the measured number; the range from low to high includes it.
By their numbers in this assay, from the lowest: compounds 2 and 4 (each within the scatter of the next); then compound 3. At a limit, above all of these: compound 1.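

In this assay, the exchange of ethyl for methoxy on an aromatic carbon, meta to a large group, now has a direct reading: a 1.1-fold higher number from compound 2 to compound 4 (0.04 log units; within the scatter). The earlier compounds shown here showed an alkoxy group only at another place on the ring, whereas this pair shows that 3-ethylphenyl and 3-methoxyphenyl cannot be told apart at this place, even though methoxy carries an oxygen and a hydrogen-bond acceptor that ethyl lacks. No measurement shown here gives a cause for this result.

Open, on these data alone, is how far this place accepts groups of another kind, such as an amine, a hydroxyl, a carboxylic acid or a longer chain like propyl, each of which would test it beyond the two small groups compared so far. Also open, as far as these compounds go, is whether methoxy and ethyl would stand as close together at another place on the ring, since the present pair speaks for this one place alone.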